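A few compounds are considered here, and "the series" means these few. Any claim that something is new, unique, unknown or untested is made for them only; others in the source may bear on it.

Compound 1 `CC(=O)N(c1nc(C)cs1)N(C(C)=O)S(=O)(=O)c1ccc(C)cc1` gives 7630 nM in a functional assay on DU-145 cells (Homo sapiens) for inhibition, read by XTT assay, with a stated time of 72 h; on this read-out higher numbers stand for weaker inhibition and lower numbers for stronger inhibition. Compound 2 `CC(=O)N(c1nc(CCl)cs1)N(C(C)=O)S(=O)(=O)c1ccc(C)cc1` reaches only a limit, > 62300 nM, in this assay. Compound 3 `CC(=O)N(c1nc(-c2ccccc2)cs1)N(C(C)=O)S(=O)(=O)c1ccc(C)cc1` likewise reaches only a limit, > 58200 nM.

Within the data shown here, compound 1 is the one measured compound that has a number; the other two values are limits. Compound 4 `CCOC(=O)c1sc(N(C(C)=O)N(C(C)=O)S(=O)(=O)c2ccc(C)cc2)nc1C` differs from compound 1 by ethoxycarbonyl in place of hydrogen on an aromatic carbon. Two measured steps alter a group on the same core and both weakened inhibition: an at least 8.1-fold higher number from compound 1 to compound 2 (0.91 log units; beyond the scatter) and an at least 7.6-fold higher number from compound 1 to compound 3 (0.88 log units; beyond the scatter). A third addition to this core is therefore expected to give a higher number, of modest size, possibly again a limit. The expected step is a 3.3-fold higher number from compound 1 to compound 4 (0.52 log units; beyond the scatter), and compound 4 is estimated at 25000 nM, between 7000 nM and 70000 nM.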

Compound 4, half-maximal inhibitory concentration: > 56900 nM
Compound 4 was reported as a limit; the forecaster's own chance of this, stated with the estimate: 40%; middle value at least 2.2-fold (0.35 log units) away from the limit.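

In this assay, compound 4 gives a limit, not a number: the limit of > 56900 nM in this assay, at which 1 of the 4 values shown sits. Ethoxycarbonyl in place of hydrogen on the aromatic carbon next to the ring sulfur gives an at least 7.4-fold higher number from compound 1 to compound 4 (0.87 log units; beyond the scatter). Inhibition is therefore also weakened by a change at this second ring position, whereas compound 2 and compound 3 differ from compound 1 only at the ring atom that bears a methyl group.

Because compound 2, compound 3 and compound 4 all give limits, the steps among them cannot be read. On these data alone, whether an amine or a carboxylic acid on this aromatic carbon would preserve inhibition remains open.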